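Replacing a methoxyphenyl with a carboxy group

The source may hold more compounds than are shown below. What is called first, only, known or untested is meant among the compounds shown, and "the series" means these compounds.

Of the compounds shown here, two have been measured in an assay on isolated protein for inhibition of alpha-ketoglutarate-dependent dioxygenase alkB homolog 3 (Homo sapiens), read by polymerase chain reaction, with a stated time of 1 h; a lower number here means a stronger inhibitor, a higher number a weaker inhibitor. Compound 1 `Cc1[nH]n(-c2nc3cc(-c4ccccc4)ccc3[nH]2)c(=O)c1Cc1ccccc1` gives 810 nM. Compound 2 `COc1ccc(Cc2c(C)[nH]n(-c3nc4ccccc4[nH]3)c2=O)cc1` gives 630 nM, and the gap between compound 2 and compound 1 lies within the usual scatter, so neither stands apart. Compound 3 `Cc1[nH]n(-c2nc3ccccc3[nH]2)c(=O)c1CC(=O)O` is not yet measured; it carries a (carboxy in place of 4-methoxyphenyl on a saturated chain carbon bound to an aromatic carbon). Within the data shown here, no measured pair shows this kind of change, so the expected step from compound 2 to compound 3 is an estimate: a moderate rise in this assay, a 4.8-fold higher number from compound 2 to compound 3 (0.68 log units; beyond the scatter). Compound 3 is therefore expected to give 3000 nM, within a range from 800 nM to 12000 nM.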

Compound 3, half-maximal inhibitory concentration: 15000 nM
Compound 3: the middle estimate sits 5.0-fold (0.70 log units) below what was measured; measured number above the stated range.
By their numbers in this assay, from the lowest: compounds 2 and 1 (each within the scatter of the next); then compound 3.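

In this assay, the saturated chain carbon bound to an aromatic carbon proves sensitive to what it carries: carboxy in place of 4-methoxyphenyl gives a 24-fold higher number from compound 2 to compound 3 (1.38 log units; beyond the scatter), a large step. Compound 1 and compound 2 both hold a six-membered aromatic ring at this place, whereas compound 3 has no ring there. No measurement shown explains the rise.

From the compounds shown here alone, whether losing the ring or gaining the carboxy group matters more remains open. A methyl ester or primary amide at this place could help separate those two changes.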